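The source may report more compounds than this note shows. Statements on the series, on what has been measured and on what is new or still open speak of the compounds shown alone.

Compound 1 `O=C(N/N=C/c1ccccc1)c1cnccn1` is the reference point of this small set. In an ADME assay on J774 cells (Mus musculus) for cytotoxicity, read by MTT assay, with a stated time of 48 h, tested at 100 ug/mL (on this read-out higher numbers stand for a weaker effect at the one concentration tested and lower numbers for a stronger effect), compound 1 gives 75%, the lowest of the three numbers recorded. Compound 3 `O=C(N/N=C/c1ccc(O)cc1)c1cnccn1` gives 81% in this assay, and the change of a number 6 percentage points higher from compound 1 to compound 3 (within the scatter) stays inside the scatter of repeated measurements. Compound 2 `O=C(N/N=C/c1ccccc1F)c1cnccn1` gives 100%, and the change of a number 25 percentage points higher from compound 1 to compound 2 (beyond the scatter) is the only one in the set that lies beyond the scatter.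

Compound 4 `N#Cc1cccc(/C=N/NC(=O)c2cnccn2)c1` is the next candidate for this assay. Within the data shown here, its single difference from compound 1 is cyano in place of hydrogen on an aromatic carbon. Both measured steps from compound 1 are likewise replacements of hydrogen on an aromatic carbon of the same ring; one of them produced a modest rise, the other nothing beyond the scatter. Among the measured compounds shown here, no cyano-bearing analogue has been measured, so the direction rests on these two precedents alone. The expectation is therefore either no change beyond the scatter or a rise of modest size, with the step from compound 1 to compound 4 estimated at a number 10 percentage points higher from compound 1 to compound 4 (within the scatter). For compound 4 the estimate in this assay is 85%, expected to fall between 65% and 100%.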

Compound 4, a percentage reported as activity, at one concentration (the size of the read-out at that concentration, not a potency): 100%
Estimate against measurement, compound 4: 15 percentage points below; the range from low to high includes it.
By their numbers in this assay, from the lowest: compounds 1 and 3 (each within the scatter of the next); then compounds 2 and 4 (each within the scatter of the next).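

In this assay, cyano on an aromatic carbon meta to a large group gives a number 25 percentage points higher from compound 1 to compound 4 (beyond the scatter), so a step beyond the scatter on this ring is not confined to the fluoro replacement. Its size matches that of a number 25 percentage points higher from compound 1 to compound 2 (beyond the scatter), but the two do not make a rule for the ring: the hydroxy replacement goes against it, with a number 6 percentage points higher from compound 1 to compound 3 (within the scatter). Nothing available explains the step seen with the cyano group.

The compounds shown leave open whether this step belongs to the cyano group itself or to its place on the ring, since no other group is shown on that same carbon. An amine, a carboxylic acid or a methoxy group at that place could separate the two readings, as could cyano on another carbon of the ring.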